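Extending the Benzylic Substituent of Compound 1 into a Hexyloxy Ether

The source may report more compounds than this note shows. Statements on the series, on what has been measured and on what is new or still open speak of the compounds shown alone.

The shared core carries a saturated chain carbon bound to an aromatic carbon, and the group on that carbon is what varies. Compound 1 `CCCCCCc1c(F)c(N)c2c(=O)cc(-c3ccc(N)c(F)c3)oc2c1F` bears a pentyl group there and in a functional assay on HeLa cells (Homo sapiens) for cytotoxicity, read by neutral red uptake, with a stated time of 3 days (on this read-out higher numbers stand for weaker inhibition and lower numbers for stronger inhibition), compound 1 gives 21000 nM, the second highest of the three numbers measured. Compound 2 `CN(C)CCCC(=O)OCc1c(F)c(N)c2c(=O)cc(-c3ccc(N)c(F)c3)oc2c1F` gives 4500 nM, and the step shows a 4.7-fold lower number from compound 1 to compound 2 (0.67 log units; beyond the scatter). Compound 3 `CCCOCc1c(F)c(N)c2c(=O)cc(-c3ccc(N)c(F)c3)oc2c1F` gives 78000 nM, with a 3.7-fold higher number from compound 1 to compound 3 (0.57 log units; beyond the scatter); between the two ethers the comparison reads a 17-fold higher number from compound 2 to compound 3 (1.24 log units; beyond the scatter).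

Compound 4 `CCCCCCOCc1c(F)c(N)c2c(=O)cc(-c3ccc(N)c(F)c3)oc2c1F` has not been measured. It differs from compound 1 by hexyloxy in place of pentyl on a saturated chain carbon bound to an aromatic carbon. The step that bears on it most closely is that from compound 1 to compound 3, where an alkoxy group likewise replaced pentyl on the same carbon and the number rose by a modest amount beyond the scatter. On that basis a modest upward step is expected, a 1.9-fold higher number from compound 1 to compound 4 (0.28 log units; within the scatter), and the estimate for compound 4 is 40000 nM, with a range from 15000 nM to 110000 nM.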

Compound 4, half-maximal inhibitory concentration: > 100000 nM
Compound 4 was reported as a limit; the forecaster's own chance of this, stated with the estimate: 5%; middle value at least 2.5-fold (0.39 log units) from the limit.
By their numbers in this assay, from the lowest: compound 2; then compound 1; then compound 3. At a limit, above all of these: compound 4.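

In this assay, compound 4 is reported only as a limit: the limit of > 100000 nM in this assay, at which 1 of the 4 values shown sits. Hexyloxy in place of pentyl gives an at least 4.7-fold higher number from compound 1 to compound 4 (0.67 log units; beyond the scatter), so a second alkoxy group on this saturated chain carbon moves the number the same way as propoxy, and the longer chain does not bring it back towards compound 1. The extra length in the ether gives an at least 1.2-fold higher number from compound 3 to compound 4 (0.10 log units; that floor lies within the scatter), which does not separate those two ethers, while hexyl in place of (3-(dimethylamino)propyl)carbonyl on the oxygen gives an at least 22-fold higher number from compound 2 to compound 4 (1.34 log units; beyond the scatter), leaving compound 2 alone at the low end of the series.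

The compounds shown leave open whether a dimethylamino group at the end of a plain ether chain, without the carbonyl, would lower the number as well. They also leave open how a shorter ether such as methoxy would read.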